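The source may hold more compounds than are shown below. What is called first, only, known or untested is meant among the compounds shown, and "the series" means these compounds.

In an ADME assay on microsomes from liver (Canis lupus familiaris) for metabolic stability (a higher number here means that the compound lasts longer, a lower number that the compound disappears faster), two compounds built on one shared core have been measured so far: compound 1 `Nc1nc(NCCNc2ncc(-c3ncc[nH]3)c(-c3ccccc3Br)n2)ccc1[N+](=O)[O-]` and compound 2 `Nc1nc(NCCNc2ncc(-c3ncc[nH]3)c(-c3ccc(Br)cc3F)n2)ccc1[N+](=O)[O-]`. Compound 1 gives > 0.5 h, which is a limit of the assay and not a number. Compound 2 gives > 0.5 h, which is also a limit. Compound 2 thus stands on (the limit of > 0.5 h in this assay, at which 2 of the 2 values shown sit), with no exact half-life known. Among the compounds with values here, the only measured step is a step that the two limits leave unreadable from compound 1 to compound 2, so the exchange of 2-bromophenyl for 4-bromo-2-fluorophenyl offers no size to carry forward.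

The unmeasured compound 3 `Cc1ccc(-c2nc(NCCNc3ccc([N+](=O)[O-])c(N)n3)ncc2-c2ncc[nH]2)c(Br)c1` keeps the shared core but changes the group on an aromatic carbon, ortho to a 1H-imidazol-2-yl group: 2-bromo-4-methylphenyl in place of 4-bromo-2-fluorophenyl on an aromatic carbon. Here, 2-bromo-4-methylphenyl takes the place of 4-bromo-2-fluorophenyl. With no readable step as a guide, no direction can be favoured in this assay. The estimated step that the limit leaves unreadable from compound 2 to compound 3 is therefore expected to stay within the usual scatter. For compound 3 the expected half-life is 0.8 h, with an estimated range from 0.4 h to 2 h. A reading reported only as a limit is the likeliest outcome.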

Compound 3, half-life: > 0.5 h
Compound 3: no number, only a limit (the forecaster's own chance of this, stated with the estimate: 85%); the middle value is on the limit's open side.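

In this assay compound 3 gives > 0.5 h, which is a limit and not a number. The steps among compound 1, compound 2 and compound 3 cannot be read, as all three stop at the same point: the limit of > 0.5 h in this assay, at which 3 of the 3 values shown sit. Going by these compounds, what stays open is the actual half-life of each compound, and whether these exchanges of groups change it at all.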